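The source may hold more compounds than are shown below. What is called first, only, known or untested is meant among the compounds shown, and "the series" means these compounds.

Measured compounds:
Compound 1 `COc1ccc(CNC(=O)/C(C#N)=C/c2ccc3ccccc3c2)cc1`: 49000 nM
Compound 2 `COc1ccc(CNC(=O)/C(C#N)=C/c2cccc3ccccc23)cc1`: 15000 nM
Compound 3 `N#C/C(=C\c1ccc2ccccc2c1)C(=O)NCc1ccc(Cl)c(Cl)c1`: 44000 nM

All three were tested in a functional assay on MIA cells (Homo sapiens) for inhibition, read by MTT assay, with a stated time of 72 h; a lower number here means a stronger inhibitor of growth, a higher number a weaker inhibitor of growth. Compound 1 and compound 2 are built from the same atoms joined differently; the difference between the two cores is not broken down here. Compound 2 shows the lowest number of the three, with compound 3 and then compound 1 both beyond the scatter above it.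

One change recurs: 3,4-dichlorophenyl in place of 4-methoxyphenyl on a saturated chain carbon bound to an amide-type nitrogen. On the core of compound 1 it gave a 1.1-fold lower number from compound 1 to compound 3 (0.05 log units; within the scatter). Compound 4 `N#C/C(=C\c1cccc2ccccc12)C(=O)NCc1ccc(Cl)c(Cl)c1` carries the same change on compound 2: 3,4-dichlorophenyl in place of 4-methoxyphenyl on a saturated chain carbon bound to an amide-type nitrogen. Because the step of a 1.1-fold lower number from compound 1 to compound 3 (0.05 log units; within the scatter) lies within the scatter, the step from compound 2 to compound 4 is expected to be small, a 1.2-fold lower number from compound 2 to compound 4 (0.06 log units; within the scatter). Compound 4 is therefore estimated at 13000 nM, expected to fall between 6000 nM and 30000 nM.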

Compound 4, concentration for 50% growth inhibition: 8000 nM
Beside the measured number, compound 4's estimate is 1.6-fold (0.21 log units) above it; low and high end bracket the measured number.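

The same replacement on the core of compound 2, 3,4-dichlorophenyl in place of 4-methoxyphenyl, gave a 1.9-fold lower number from compound 2 to compound 4 (0.27 log units; within the scatter). In this assay, among these compounds, the two cores respond alike, the two steps differing by no more than repeated measurements allow: the same change on two cores in this assay, a 1.1-fold lower number (0.05 log units; within the scatter) from compound 1 to compound 3 and a 1.9-fold lower number (0.27 log units; within the scatter) from compound 2 to compound 4, 1.7-fold (0.23 log units) apart, within the scatter of two such steps This shows that the change carried from one core to the other without a detectable difference, but it rests on only two pairs, with both steps within the scatter, so it shows neither a real effect of the change on growth inhibition nor that the same would hold on any further core.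

Open, as far as these compounds go, is how an amine or a carboxylic acid on the phenyl ring would fare. From the compounds shown here alone, a longer chain in place of the single saturated chain carbon is equally open.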